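The compounds below may be only part of what the source reports. "The series", "measured", "known", "first", "only" and "open" are said of these compounds alone.

Measured in a functional assay on the whole organism for antagonist activity, with Rattus norvegicus as the target (on this read-out lower numbers stand for an effect already at smaller amounts and higher numbers for an effect only at larger amounts of compound), so far:

compound 1 `CN(C)c1ncnc2c1ncn2CC1CC1` gives 4.5 mg/kg
compound 2 `CCN(C)c1ncnc2c1ncn2CC1CC1` gives 12.5 mg/kg
compound 3 `O=CN(c1ncnc2c1ncn2CC1CC1)C1CC1` gives 8 mg/kg

Compound 3 holds the second highest number of the three. Its nearest neighbour is compound 2, with a 1.6-fold lower number from compound 2 to compound 3 (0.19 log units; within the scatter); its furthest is compound 1, with a 1.8-fold higher number from compound 1 to compound 3 (0.25 log units; within the scatter). Neither gap clears the scatter, so compound 3 cannot be told apart from either on this read-out. Within the data shown here, the one step that does clear the scatter, a 2.8-fold higher number from compound 1 to compound 2 (0.44 log units; beyond the scatter), concerns the group on the aromatic carbon.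

Compound 4 `O=CN(c1ncnc2c1ncn2C1CCC1)C1CC1` is the next compound; it differs from compound 3 by cyclobutyl in place of cyclopropylmethyl on an aromatic nitrogen. Among the measured compounds shown here, all three measured steps change the substituent on the aromatic carbon and leave the group on the aromatic nitrogen untouched, so no measured step bears directly on this change. For the measured compounds named here, the only guidance is the narrow spread of the series as a whole, within which every compound so far falls inside a modest band.

With nothing pointing in either direction, the step of no change at the digits printed from compound 3 to compound 4 (within the scatter) is expected to stay within the scatter, and compound 4 is estimated at 8 mg/kg in this assay, with a range from 3 mg/kg to 20 mg/kg.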

Compound 4, dose for half-maximal effect: 20 mg/kg
Beside the measured number, compound 4's estimate is 2.5-fold (0.40 log units) below it; measured number inside the range.
By their numbers in this assay, from the lowest: compounds 1, 3, 2 and 4 (each within the scatter of the next, the first and the last beyond it).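

The group on the aromatic nitrogen proves to be a position where the read-out can move: cyclobutyl in place of cyclopropylmethyl gives a 2.5-fold higher number from compound 3 to compound 4 (0.40 log units; beyond the scatter) in this assay. Among these compounds, the earlier steps all changed the group on the aromatic carbon, and the only one beyond the scatter was a 2.8-fold higher number from compound 1 to compound 2 (0.44 log units; beyond the scatter), so this is the first sign that the series also responds at the aromatic nitrogen, with a step printed as modest like that one. The two groups have the same atoms and the same heavy-atom count, and neither has hydrogen-bond donors or acceptors, so rearranging those atoms into a four-membered ring in place of a three-membered ring on a methylene link is enough to clear the scatter, though nothing measured here accounts for the shift.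

From the compounds shown here alone, it remains open whether the step at this nitrogen keeps its direction and size with dimethylamino or ethyl(methyl)amino on the aromatic carbon in place of cyclopropyl(formyl)amino. Also open, going by these compounds, is how the read-out responds to other groups on the aromatic nitrogen, such as cyclopentyl, a longer chain like butyl, or a chain ending in an amine.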